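Compound 3, the mirror image of compound 2

The source may report more compounds than this note shows. Statements on the series, on what has been measured and on what is new or still open speak of the compounds shown alone.

In an ADME assay on the whole organism (Mus musculus, strain C57BL/6) for pharmacokinetics, read by HPLC, with a stated time of 6 h, at a dose of 25 mg/kg by the oral route (a lower number here means less compound in the circulation, a higher number more compound in the circulation at the dose given), compound 2 `O=C(O)[C@@H](CO)NC(=O)[C@H]1C[C@H](O)CN1` gives 22900 nM and stands highest of the two measured, while compound 1 `O=C(O)[C@H](CO)NC(=O)[C@H]1C[C@H](O)CN1` gives 4010 nM and stands lower. Compound 3 `O=C(O)[C@H](CO)NC(=O)[C@@H]1C[C@@H](O)CN1` is related to compound 2 as follows: the two compounds have the same atoms and bonds and differ only in configuration as drawn: 3 of 3 stereo elements differ (all stereocentres are inverted: mirror images); a stereocentre at a saturated chain carbon is drawn R in compound 2 and S in compound 3; a stereocentre at a saturated ring carbon is drawn R in compound 2 and S in compound 3; a stereocentre at a saturated ring carbon is drawn S in compound 2 and R in compound 3 and no atom or bond changes. Within the data shown here, the one measured step bearing on this is a 5.7-fold higher number from compound 1 to compound 2 (0.76 log units; beyond the scatter) with only the chain carbon inverted, and compound 3 keeps that carbon as drawn in compound 1, so a lower number is expected. Among the measured compounds shown here, the ring carbons have no measured step. The expected step is a 3.8-fold lower number from compound 2 to compound 3 (0.58 log units; beyond the scatter) and its size is uncertain. Compound 3 is estimated at 6000 nM with an expected range of 1500 nM to 22000 nM in this assay here.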

Compound 3, maximal plasma concentration: 520 nM
Beside the measured number, compound 3's estimate is 12-fold (1.06 log units) above it; the whole stated range lies above it.
By their numbers in this assay, from the lowest: compound 3; then compound 1; then compound 2.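

In this assay the two ring carbons now have a measured step of their own, with the chain carbon as drawn unchanged: a 7.7-fold lower number from compound 1 to compound 3 (0.89 log units; beyond the scatter). Inverting all three stereocentres gives a 44-fold lower number from compound 2 to compound 3 (1.64 log units; beyond the scatter), so the number follows the ring carbons as well as the chain carbon, and the configuration of compound 2 stands highest of the three.

The two ring carbons change together here, so the share of each remains unresolved. Also open, on these data alone, is whether this order by configuration holds with a methyl ester in place of the carboxylic acid.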